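The source may hold more compounds than are shown below. What is called first, only, known or untested is meant among the compounds shown, and "the series" means these compounds.

In a functional assay on RAW264.7 cells (Mus musculus) for inhibition (a lower number here means a stronger inhibitor, a higher number a weaker inhibitor), compound 2 `COc1cc(/C=C/C(=O)CC(=O)/C=C/c2ccc(OC(=O)C(C)c3ccc(CC(C)C)cc3)c(OC)c2)ccc1O` reads > 30000 nM, and this is a limit, not a number. That places it at the limit of > 30000 nM in this assay, at which 1 of the 3 values shown sits, so any step away from compound 2 can only be sized from one side. The step to compound 4 `COc1cc(/C=C/C(=O)CC(=O)/C=C/c2ccc(OC(=O)c3ccccc3O)c(OC)c2)ccc1O` puts 2-hydroxyphenyl in place of 1-(4-isobutylphenyl)ethyl on a carbonyl carbon.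

One measured step starts from the same compound. Compound 3 `COc1cc(/C=C/C(=O)CC(=O)/C=C/c2ccc(OC(=O)C(C)c3ccc(C(=O)c4ccccc4)cc3)c(OC)c2)ccc1O`, with benzoyl in place of isobutyl on an aromatic carbon, gives 8980 nM, which amounts to an at least 3.3-fold lower number from compound 2 to compound 3 (0.52 log units; beyond the scatter). That step shows that compound 2 can be left behind by a change in the same group, although it does not replace that group with 2-hydroxyphenyl. The nearest evidence for the entering group is compound 1 `COc1cc(/C=C/C(=O)CC(=O)/C=C/c2ccc(OC(=O)c3ccccc3O)c(OC)c2)ccc1OC(=O)c1ccccc1O`, which also carries 2-hydroxyphenyl on a carbonyl carbon and gives 6110 nM.

With compound 1 at 6110 nM and the step to compound 3 as a guide, a step beyond the scatter towards a lower number is expected. The expected change is an at least 4.2-fold lower number from compound 2 to compound 4 (0.63 log units; beyond the scatter). Compound 4 is estimated at 7000 nM, with an expected range of 2500 nM to 20000 nM.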

Compound 4, half-maximal inhibitory concentration: > 30000 nM
Compound 4: a limit, no number; the forecaster's own chance of this, stated with the estimate: 15%; at least 4.2-fold (0.63 log units) between middle value and limit.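

In this assay compound 4 is read only as a limit, not a number, and it now shares that limit with compound 2: the limit of > 30000 nM in this assay, at which 2 of the 4 values shown sit. The step between these two compounds cannot be read, so 2-hydroxyphenyl in place of 1-(4-isobutylphenyl)ethyl on a carbonyl carbon is not shown to lower the number at all, unlike benzoyl in place of isobutyl on an aromatic carbon earlier in the series. The earlier compounds shown here also did not show that 2-hydroxyphenyl on this carbonyl carbon is not enough by itself for a value within the range of the assay: hydrogen in place of the second (2-hydroxyphenyl)carbonyl, on an oxygen on an aromatic ring, gives an at least 4.9-fold higher number from compound 1 to compound 4 (0.69 log units; beyond the scatter).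

From the compounds shown here alone, whether a carboxylic acid or an amine carried on this same carbonyl carbon would bring the number under the limit stays open. Going by these compounds, it also stays open whether the second (2-hydroxyphenyl)carbonyl matters as that particular group, or whether a simple acetyl on the same oxygen would give a similar reading.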